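A few compounds are considered here, and "the series" means these few. Any claim that something is new, unique, unknown or untested is made for them only; others in the source may bear on it.

In a functional assay on HT-1080 cells (Homo sapiens) for antiproliferative activity, read by MTT assay, with a stated time of 72 h (a higher number here means a weaker inhibitor, a lower number a stronger inhibitor), compound 1 `COc1cc(-c2cc(C(=O)O)sc2-c2cccc(Br)c2)cc(OC)c1OC` reports only a limit, > 100000 nM. Compound 2 `COc1ccc(-c2sc(C(=O)O)cc2-c2cc(OC)c(OC)c(OC)c2)cc1OCc1ccccc1` also reports only a limit, > 100000 nM. Compound 3 `COc1ccc(-c2sc(C(=O)O)cc2-c2cc(OC)c(OC)c(OC)c2)cc1O` alone has a true number, 7510 nM. Two measured steps lead to it: an at least 13-fold lower number from compound 1 to compound 3 (1.12 log units; beyond the scatter), and an at least 13-fold lower number from compound 2 to compound 3 (1.12 log units; beyond the scatter). Compound 4 `COc1ccc(-c2sccc2-c2cc(OC)c(OC)c(OC)c2)cc1O` has hydrogen in place of carboxy on an aromatic carbon, (hydrogen in place of carboxy on an aromatic carbon). All three measured compounds carry the carboxy, so neither step tests its removal. Within the data shown here, they show only that single changes can move this assay by large amounts. A tentative expectation is a lower number, on a similar scale, with wide uncertainty. The estimated change is a 15-fold lower number from compound 3 to compound 4 (1.18 log units; beyond the scatter). Compound 4 is expected near 500 nM, with an estimated range from 30 nM to 7000 nM.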

Compound 4, half-maximal inhibitory concentration: 1940 nM
Estimate against measurement, compound 4: 3.9-fold (0.59 log units) below, and the stated range covers the measured number.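

Putting hydrogen in place of the carboxy on the aromatic carbon next to the ring sulfur gives a 3.9-fold lower number from compound 3 to compound 4 (0.59 log units; beyond the scatter), so in this compound the carboxy is not needed for activity. Among these compounds, this is also the first step here with a true number at both ends, which lets its size be read directly. Each earlier step starts from a limit: the limit of > 100000 nM in this assay, at which 2 of the 4 values shown sit.

On these data alone, whether an amide or an amine at this position would give a lower number stays open. So does whether removing the carboxy changes the number by a similar amount in compounds with other aryl groups.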